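The source may hold more compounds than are shown below. What is called first, only, known or untested is meant among the compounds shown, and "the series" means these compounds.

Three compounds share one core and differ only at the amide end. In a functional assay on A549 cells (Homo sapiens) for inhibition, read by MTT assay, with a stated time of 72 h (on this read-out lower numbers stand for stronger inhibition and higher numbers for weaker inhibition), compound 2 `C=CC(=O)Nc1cccc(Oc2nc(Nc3cccc(C#N)c3)nc3ccsc23)c1` gives 4340 nM, compound 3 `C/C=C/C(=O)Nc1cccc(Oc2nc(Nc3cccc(C#N)c3)nc3ccsc23)c1` gives 11300 nM, and compound 1 `COc1cccc(Nc2nc(Oc3cccc(NC(=O)C=C(C)C)c3)c3sccc3n2)c1` gives 27700 nM. Compound 3 thus stands second highest of the three, with compound 1 higher and compound 2 lower. Within the data shown here, the one step that bears on the next change is a 2.6-fold higher number from compound 2 to compound 3 (0.42 log units; beyond the scatter). Compound 4 `CC(C)=CC(=O)Nc1cccc(Oc2nc(Nc3cccc(C#N)c3)nc3ccsc23)c1` takes the same direction one step further: 2-methylprop-1-en-1-yl in place of prop-1-en-1-yl on a carbonyl carbon. Compound 1, which also carries 2-methylprop-1-en-1-yl on its carbonyl carbon but a different remainder, shows the highest number of all. A further modest rise is therefore expected, a 1.8-fold higher number from compound 3 to compound 4 (0.25 log units; within the scatter). Compound 4 is estimated at 20000 nM, with a likely range from 8000 nM to 50000 nM.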

Compound 4, half-maximal inhibitory concentration: 16900 nM
Compound 4: the middle estimate sits 1.2-fold (0.07 log units) above what was measured; low and high end bracket the measured number.
By their numbers in this assay, from the lowest: compound 2; then compounds 3, 4 and 1 (each within the scatter of the next, the first and the last beyond it).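

Putting 2-methylprop-1-en-1-yl in place of prop-1-en-1-yl on the carbonyl carbon gives a 1.5-fold higher number from compound 3 to compound 4 (0.17 log units; within the scatter) in this assay, so this last change cannot be told apart from repeat variation, while the full change from vinyl gives a 3.9-fold higher number from compound 2 to compound 4 (0.59 log units; beyond the scatter). Elsewhere in the molecule, with this same amide group, cyano in place of methoxy on an aromatic carbon gives a 1.6-fold lower number from compound 1 to compound 4 (0.21 log units; within the scatter), which is also no clear change. Still open, on these data alone, is how a longer chain or an amine on the carbonyl carbon would compare. Nothing available explains why these numbers differ.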